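A fluoro step from compound 2 to compound 3

The source may hold more compounds than are shown below. What is called first, only, known or untested is meant among the compounds shown, and "the series" means these compounds.

Compound 1 `O=C1NC(=O)C(c2ccc(-c3ccc4ccccc4c3)[nH]c2=O)O1` gives 5.1 h in half-life
Compound 2 `CC(C)C1(c2ccc(-c3ccc4ccccc4c3)[nH]c2=O)OC(=O)NC1=O` gives 4 h in half-life

Among the compounds with values here, in an in vivo ADME assay on the whole organism (strain Sprague-Dawley) for metabolic stability, with Rattus norvegicus as the target, at a dose of 1 mg/kg by the intravenous route (a higher number here means that the compound lasts longer, a lower number that the compound disappears faster), compound 2 stands within the scatter of compound 1, the only other measured compound, with a 1.3-fold lower number from compound 1 to compound 2 (0.11 log units; within the scatter) as the whole gap between them. Within the data shown here, compound 3 `CC(C)C1(c2ccc(-c3ccc4cccc(F)c4c3)[nH]c2=O)OC(=O)NC1=O` differs from compound 2 by fluoro in place of hydrogen on an aromatic carbon as its single change, fluoro in place of hydrogen on an aromatic carbon. Among the measured compounds shown here, the one measured step concerns isopropyl in place of hydrogen on a saturated ring carbon, and no measured step shows fluoro on an aromatic carbon, so no step beyond the scatter is expected in this assay here. The expected step is a 1.1-fold higher number from compound 2 to compound 3 (0.05 log units; within the scatter) by this estimate. Compound 3 is expected at 4.5 h as its half-life, within an estimated range from 2.5 h to 8 h for this measurement.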

Compound 3, half-life: 3.9 h
The estimate for compound 3 lay 1.2-fold (0.06 log units) above the measured number; the range from low to high includes it.
By their numbers in this assay, from the lowest: compounds 3, 2 and 1 (each within the scatter of the next).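

In this assay, placing fluoro in place of hydrogen on this aromatic carbon, ortho to a fused ring, gives a 1.0-fold lower number from compound 2 to compound 3 (0.01 log units; within the scatter). Within the data shown here, the earlier compounds showed only a change on the saturated ring carbon; this is the first sign that the aromatic part can take a single fluoro with no step beyond the scatter. Nothing at hand gives a reason for this result. The compounds shown leave open whether a chloro, methoxy or nitrile group on the same carbon would also stay within the scatter of compound 2, and whether fluoro elsewhere on that ring would.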